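A few compounds are considered here, and "the series" means these few. Any claim that something is new, unique, unknown or untested is made for them only; others in the source may bear on it.

In a functional assay on CHO cells for agonist activity at Melanocortin receptor 4 (Homo sapiens), read by a luciferase reporter, with a stated time of 4 h (on this read-out higher numbers stand for an effect only at larger amounts of compound and lower numbers for an effect already at smaller amounts), compound 1 `O=C1C(Cc2n[nH]c3cc(F)ccc23)C(=O)N(c2ccccc2)C=CN1CC(=O)N1CCCCc2ccccc21` gives 437 nM, the highest of the two numbers recorded; compound 2 `O=C1C(Cc2n[nH]c3ccccc23)C(=O)N(c2ccccc2)C=CN1CC(=O)N1CCCCc2ccccc21` gives 324 nM, and the step of a 1.3-fold lower number from compound 1 to compound 2 (0.13 log units; within the scatter) is within the scatter. Compound 3 `CC(C)N(C(=O)CN1C=CN(c2ccccc2)C(=O)C(Cc2n[nH]c3cc(F)ccc23)C1=O)c1ccc(F)cc1` differs from compound 1 by a group of 11 heavy atoms (9 carbon, 1 nitrogen, 1 fluorine; one six-membered aromatic ring of carbon only) in place of a group of 11 heavy atoms (10 carbon, 1 nitrogen; one six-membered aromatic ring of carbon only, one seven-membered non-aromatic ring with 1 hetero atom), on a carbonyl carbon. For the measured compounds named here, no measured step touches this place; the only recorded step changes a fluoro on an aromatic carbon elsewhere, so it says nothing about the present change, and no direction can be read from it. For compound 3 the expected value in this assay is 550 nM (range 120 nM to 2500 nM), i.e. an expected step of a 1.3-fold higher number from compound 1 to compound 3 (0.10 log units; within the scatter) with wide uncertainty.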

Compound 3, half-maximal effective concentration: 178 nM
Compound 3: the middle estimate sits 3.1-fold (0.49 log units) above what was measured, and the stated range covers the measured number.
By their numbers in this assay, from the lowest: compounds 3, 2 and 1 (each within the scatter of the next, the first and the last beyond it).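

This place on the carbonyl carbon responds where the earlier fluoro step did not: in this assay the change gives a 2.5-fold lower number from compound 1 to compound 3 (0.39 log units; beyond the scatter). The group with the seven-membered non-aromatic ring is therefore not needed to keep this level of agonist activity in the core of compound 1. No available measurement bears on what lies behind this step. Open, on these data alone, is whether a piperidine or a dimethylamino group on the same carbonyl carbon would move the number further. Also open, as far as these compounds go, is whether the step carries over to the core of compound 2.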